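Hydroxy for amino on compound 3

The compounds below may be only part of what the source reports. "The series", "measured", "known", "first", "only" and "open" are said of these compounds alone.

Going by the values given here, three related compounds have numbers so far in a functional assay on HCT-116 cells (Homo sapiens) for antiproliferative activity; on this read-out higher numbers stand for weaker inhibition and lower numbers for stronger inhibition. Compound 1 `CC(=O)N1CCCc2c(C)c3c(n2-c2ccc(C(N)=O)c(c2)N[C@@H](C)[C@@H]1C)CC(C)(C)CC3=O` gives 27 nM, compound 2 `CC(=O)N1CCc2c(C)c3c(n2-c2ccc(C(N)=O)c(c2)N[C@@H](C)[C@H](C)C1)CC(C)(C)CC3=O` gives 24 nM, and compound 3 `Cc1c2c(n3c1CCN(C(=O)[C@@H](N)C(C)C)C[C@@H](C)[C@H](C)Nc1cc-3ccc1C(N)=O)CC(C)(C)CC2=O` gives 30 nM. These three numbers lie within the usual scatter of one another, so compound 3 stands level with the other two and none can be ranked above the rest.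

Compound 4 `Cc1c2c(n3c1CCN(C(=O)[C@@H](O)C(C)C)C[C@@H](C)[C@H](C)Nc1cc-3ccc1C(N)=O)CC(C)(C)CC2=O` differs from compound 3 in a single group: hydroxy in place of amino on a saturated chain carbon bound to a carbonyl carbon and a saturated chain carbon. Put simply, this is hydroxy in place of amino on a saturated chain carbon bound to a carbonyl carbon and a saturated chain carbon.

Among the compounds with values here, one measured step bears on this place: a 1.3-fold higher number from compound 2 to compound 3 (0.10 log units; within the scatter). There, 1-amino-2-methylpropyl took the place of methyl on a carbonyl carbon, and the number stayed within the scatter. Within the data shown here, no measured pair trades amino for hydroxy directly, so this evidence is only indirect. Going by that single step, no change beyond the scatter is expected in this assay. The expected step is a 1.1-fold lower number from compound 3 to compound 4 (0.03 log units; within the scatter). For compound 4 the estimated value is 28 nM, with an expected range from 12 nM to 65 nM.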

Compound 4, half-maximal inhibitory concentration: 45 nM
The estimate for compound 4 lay 1.6-fold (0.21 log units) below the measured number; the range from low to high includes it.
By their numbers in this assay, from the lowest: compounds 2, 1, 3 and 4 (each within the scatter of the next).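

In this assay, going by these compounds alone, this is the first direct measurement of hydroxy in place of amino on a saturated chain carbon bound to a carbonyl carbon and a saturated chain carbon, and the exchange gives a 1.5-fold higher number from compound 3 to compound 4 (0.18 log units; within the scatter), so the read-out does not separate the two groups at this place. A second comparison, which swaps the plain methyl for 1-hydroxy-2-methylpropyl, gives a 1.9-fold higher number from compound 2 to compound 4 (0.27 log units; within the scatter), and this too stays within the usual scatter, so the hydroxy-bearing group, like the amino-bearing one before it, leaves the antiproliferative number level with that of the plain methyl. No accompanying measurement offers an explanation for these numbers.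

The compounds shown leave open whether a methoxy group, a dimethylamine or a carboxylic acid on that same saturated chain carbon would also stay within the scatter, or would instead move the number beyond it. They also leave open whether a longer chain in place of the 2-methylpropyl part of the side group, or the opposite spatial arrangement at the carbon carrying the hydroxy or amino group, would give a different result.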